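Swapping 4-methylphenyl for 3,4,5-trimethoxyphenyl on compound 2

The source may hold more compounds than are shown below. What is called first, only, known or untested is meant among the compounds shown, and "the series" means these compounds.

Of the compounds shown here, two have been tested so far in a functional assay on HT-29 cells (Homo sapiens) for cytotoxicity, read by MTT assay; on this read-out lower numbers stand for stronger inhibition and higher numbers for weaker inhibition. Compound 1 `COc1ccc(OC)c(C(=O)/C=C/c2ccoc2)c1` gives 21300 nM, and compound 2 `COc1ccc(OC)c(C(=O)/C=C/c2ccc(OC(=O)/C=C/c3ccc(C)cc3)cc2)c1` gives 16400 nM. These two numbers lie within the usual scatter of repeated measurements, so compound 2 cannot be ranked apart from compound 1, even though their structures differ in more than one place.

The next compound changes a single place. In compound 3 `COc1ccc(OC)c(C(=O)/C=C/c2ccc(OC(=O)/C=C/c3cc(OC)c(OC)c(OC)c3)cc2)c1`, 3,4,5-trimethoxyphenyl takes the place of 4-methylphenyl on a double-bonded chain carbon bound to a double-bonded chain carbon: 3,4,5-trimethoxyphenyl in place of 4-methylphenyl on a double-bonded chain carbon bound to a double-bonded chain carbon.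

Within the data shown here, no measured pair yet shows a change of this kind, so the size of the step can only be judged loosely. Among the measured compounds shown here, the one guide is that compound 2, at 16400 nM, stays within the scatter of compound 1 despite their different structures. No step beyond the scatter is therefore expected, with only a slight lean toward stronger inhibition. The estimated change is a 1.4-fold lower number from compound 2 to compound 3 (0.14 log units; within the scatter). For compound 3 the expected value is 12000 nM, with an estimated range of 4000 nM to 32000 nM.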

Compound 3, half-maximal inhibitory concentration: 23800 nM
Compound 3: the middle estimate sits 2.0-fold (0.30 log units) below what was measured; low and high end bracket the measured number.
By their numbers in this assay, from the lowest: compounds 2, 1 and 3 (each within the scatter of the next).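

In this assay, among these compounds, swapping 4-methylphenyl for 3,4,5-trimethoxyphenyl gives a 1.5-fold higher number from compound 2 to compound 3 (0.16 log units; within the scatter), and this is the first comparison here that isolates a single place. The entering group has 12 heavy atoms and 3 hydrogen-bond acceptors, whereas the leaving group has 7 heavy atoms and 0 hydrogen-bond acceptors, yet the two compounds remain within the usual scatter of each other, so this pair shows no measurable separation for this swap at this position. Nothing available here explains why the two compounds read alike.

Among the compounds shown here, this pair covers only two substituted phenyl groups at this position, so it remains open whether a phenyl group carrying an amine or a carboxylic acid would give a step beyond the scatter. From the compounds shown here alone, it is also open how a longer alkyl chain in place of the aromatic ring would read, and so whether any change at this position can separate compounds in this assay.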